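Ethoxy to Difluoromethoxy: What to Expect for Compound 4

The source may report more compounds than this note shows. Statements on the series, on what has been measured and on what is new or still open speak of the compounds shown alone.

Compound 1 `CCc1nc(-c2ccc(Cl)cc2Cl)c(CC)nc1CC(CC)CC`: 0.0417 h
Compound 2 `CCOc1ccc(-c2nc(OC)c(NC(CC)CC)nc2C)c(Cl)c1`: 0.783 h
Compound 3 `CCc1nc(-c2ccc(Cl)cc2Cl)c(CC)nc1NC(COC)COC`: 0.0417 h

Among the three compounds measured in an in vitro ADME assay on microsomes (Rattus norvegicus) for metabolic stability (a higher number here means that the compound lasts longer, a lower number that the compound disappears faster), compound 2 stands highest, with compound 1 and compound 3 both far lower. For the measured compounds named here, the one measured step, no change at the digits printed from compound 1 to compound 3 (within the scatter), concerns a different position and shows nothing beyond the scatter. Compound 4 `CCC(CC)Nc1nc(C)c(-c2ccc(OC(F)F)cc2Cl)nc1OC` differs from compound 2 by difluoromethyl in place of ethyl on an oxygen on an aromatic ring. Going by the values given here, no measured step bears on that exchange, so there is no precedent in this assay for its size or direction. The expectation therefore rests on compound 2 alone, and the step from it is estimated as a 1.3-fold higher number from compound 2 to compound 4 (0.11 log units; within the scatter), not beyond the scatter. Compound 4 is estimated to give 1 h, with a range from 0.4 h to 2.5 h.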

Compound 4, half-life: 0.8 h
For compound 4 the middle estimate is 1.3-fold (0.10 log units) above the measured one; low and high end bracket the measured number.
By their numbers in this assay, from the lowest: compounds 1 and 3 (each within the scatter of the next); then compounds 2 and 4 (each within the scatter of the next).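

In this assay, for the compounds shown here, the exchange of ethoxy for difluoromethoxy gives the first reading at this position, and it reads a 1.0-fold higher number from compound 2 to compound 4 (0.01 log units; within the scatter) so that the two compounds cannot be told apart by half-life. Difluoromethyl on this oxygen is therefore tolerated in this assay as well as ethyl is, at least on the core of compound 2. Nothing shown explains this outcome. As far as these compounds go, whether trifluoromethyl or a longer chain such as propyl on the same oxygen would read alike remains open. So does whether the exchange would read the same on a different core.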